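The source may report more compounds than this note shows. Statements on the series, on what has been measured and on what is new or still open speak of the compounds shown alone.

Measured compounds:
Compound 1, `O=C(/C=C/c1ccc(Br)cc1)NNC(=O)c1ccc2c(c1)OCCO2`, gives 2330 nM.
Compound 2, `O=C(/C=C/c1ccccc1Br)NNC(=O)c1ccc2c(c1)OCCO2`, gives 2110 nM.
Compound 3, `O=C(/C=C/c1ccccc1[N+](=O)[O-])NNC(=O)c1ccc2c(c1)OCCO2`, gives 890 nM.

In a functional assay on cells (Cancer cell lines, Homo sapiens) for inhibition, read by MTT assay, with a stated time of 48 h (a lower number here means a stronger inhibitor, a higher number a weaker inhibitor), compound 2 stands second highest of the three numbers. Its nearest neighbour is compound 1, with a 1.1-fold lower number from compound 1 to compound 2 (0.04 log units; within the scatter), a move from 4-bromophenyl to 2-bromophenyl that makes no difference beyond the scatter. Its furthest neighbour is compound 3, reached by a 2.4-fold lower number from compound 2 to compound 3 (0.37 log units; beyond the scatter), a modest but real shift when nitro replaces bromo on an aromatic carbon.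

Compound 4, `Cc1ccccc1/C=C/C(=O)NNC(=O)c1ccc2c(c1)OCCO2`, has not yet been measured. It differs from compound 2 in one place: methyl in place of bromo on an aromatic carbon. Going by the values given here, the only step that directly bears on it is the exchange at the same aromatic carbon from compound 2 to compound 3, where the replacement of bromo by nitro brought a modest fall in the number. Methyl is not nitro, however, and the two bromophenyl compounds sit within the scatter of one another, so the shown steps give no firm ground for a move in either direction. A step within the scatter is therefore expected, a 1.1-fold higher number from compound 2 to compound 4 (0.06 log units; within the scatter). Compound 4 is estimated at 2400 nM, within a range from 1200 nM to 4800 nM.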

Compound 4, half-maximal inhibitory concentration: 7710 nM
The estimate for compound 4 lay 3.2-fold (0.51 log units) below the measured number, outside the stated range (above it).
By their numbers in this assay, from the lowest: compound 3; then compounds 2 and 1 (each within the scatter of the next); then compound 4.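

In this assay, the group on this aromatic carbon, ortho to a large group, clearly matters: methyl in place of bromo gives a 3.7-fold higher number from compound 2 to compound 4 (0.56 log units; beyond the scatter) and methyl in place of nitro gives an 8.7-fold higher number from compound 3 to compound 4 (0.94 log units; beyond the scatter), so the three groups compared at this one place now rank nitro, bromo and methyl by rising number, each step beyond the scatter. Before this, the only exchange of group at this carbon was nitro for bromo, and only in the direction of a lower number; compound 4 shows that a change here can also raise the number, and it stands apart from the 4-bromophenyl compound too (a 3.3-fold higher number from compound 1 to compound 4 (0.52 log units; beyond the scatter)), which makes it the weakest of the four compounds in this assay. No accompanying data bear on why methyl gives the highest number of the three groups.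

From the compounds shown here alone, whether an amine or a carboxylic acid on this aromatic carbon would fall nearer to nitro or to methyl remains open. Also open, going by these compounds, is whether moving methyl around the ring would matter as little as moving bromo did (a 1.1-fold lower number from compound 1 to compound 2 (0.04 log units; within the scatter)).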